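The source may hold more compounds than are shown below. What is called first, only, known or untested is meant among the compounds shown, and "the series" means these compounds.

Measured compounds and their values:
Compound 1 `COc1cc2c(Oc3ccc(NC(=O)c4nn(-c5ccc(F)cc5)c(=O)c5ccccc45)cc3F)ccnc2cc1OCCCN1CCN(C)CC1` gives 460 nM in a functional assay on MDA-MB-231 cells (Homo sapiens) for cytotoxicity, read by MTT assay, with a stated time of 72 h; on this read-out higher numbers stand for weaker inhibition and lower numbers for stronger inhibition.
Compound 2 `COc1cc2c(Oc3ccc(NC(=O)c4nn(-c5ccc(Br)cc5)c(=O)c5ccccc45)cc3F)ccnc2cc1OCCCN1CCN(C)CC1` gives 1370 nM in this assay.

Compound 1 gives the lowest of the two numbers seen so far; its nearest neighbour is compound 2, and the change of a 3.0-fold higher number from compound 1 to compound 2 (0.47 log units; beyond the scatter) lies beyond the scatter. Compound 3 `COc1cc2c(Oc3ccc(NC(=O)c4nn(-c5ccc(F)cc5)c(=O)c5ccccc45)cc3F)ccnc2cc1OCCCN1CCC(C)CC1` has not yet been measured. It differs from compound 1 by 4-methylpiperidin-1-yl in place of 4-methylpiperazin-1-yl on a saturated chain carbon, three bonds along the chain from an oxygen on an aromatic ring. Within the data shown here, the only measured step, from compound 1 to compound 2, concerns a halogen on an aromatic ring and not the chain end, so no measured step bears directly on this change, and the size of the effect of swapping a piperazine for a piperidine at this position is unknown here. The expectation is therefore a step of a 1.4-fold higher number from compound 1 to compound 3 (0.15 log units; within the scatter) in this assay, a direction that is not supported by any measured pair and carries wide uncertainty. Compound 3 is estimated to give 650 nM, within a range from 230 nM to 1800 nM.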

Compound 3, half-maximal inhibitory concentration: 660 nM
Estimate against measurement, compound 3: 1.0-fold (0.01 log units) below, within the range that was stated.
By their numbers in this assay, from the lowest: compounds 1 and 3 (each within the scatter of the next); then compound 2.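

The step at the chain end, a 1.4-fold higher number from compound 1 to compound 3 (0.16 log units; within the scatter) in this assay, shows that on this saturated chain carbon, three bonds along the chain from an oxygen on an aromatic ring, 4-methylpiperidin-1-yl can replace 4-methylpiperazin-1-yl with the two values remaining within the scatter of each other. This exchange takes one ring nitrogen and one hydrogen-bond acceptor out of the group, yet only the halogen exchange, a 3.0-fold higher number from compound 1 to compound 2 (0.47 log units; beyond the scatter), so far gives a step beyond the scatter. No evidence is available that bears on this result.

From the compounds shown here alone, it remains open how a morpholin-4-yl group, an unsubstituted piperazine or a shorter or longer chain would read at this position. Going by these compounds, it is also open whether the same exchange would give a similar step in the bromo compound, compound 2.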